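Thiazolyl Ethoxy Chain in Place of Trifluorophenyl: Clearance Outlook

This account rests on a few compounds, and the source may have more. Where it says the series, first, only, none or still open, it means among the compounds named here.

Compound 3 `Cc1nc(C)c([C@H](OC(C)(C)C)C(=O)O)c(N2CCC(C)(C)CC2)c1-c1ccc(OCCc2cc(F)c(F)cc2F)cc1` was measured in an ADME assay on the whole organism (Rattus norvegicus, strain Sprague-Dawley) for pharmacokinetics, read by LC-MS, at a dose of 1 mg/kg by the intravenous route (a higher number here means faster removal of the compound, a lower number slower removal), where compound 3 gives 8.1 mL/min/kg. Among the three measured compounds it holds the second highest number. Compound 1 `Cc1cc(CCOc2ccc(-c3c(C)nc(C)c([C@H](OC(C)(C)C)C(=O)O)c3N3CCC(C)(C)CC3)cc2)ccc1F` gives 7.8 mL/min/kg; the step of a 1.0-fold higher number from compound 1 to compound 3 (0.02 log units; within the scatter) lies within the scatter. Compound 2 `Cc1nc(C)c([C@H](OC(C)(C)C)C(=O)O)c(N2CCC(C)(C)CC2)c1-c1ccc(OCCc2cc(F)ccc2F)cc1` gives 18.7 mL/min/kg; the step of a 2.3-fold lower number from compound 2 to compound 3 (0.36 log units; beyond the scatter) is beyond the scatter, as is a 2.4-fold higher number from compound 1 to compound 2 (0.38 log units; beyond the scatter).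

Compound 4 `Cc1nc(C)c(CCOc2ccc(-c3c(C)nc(C)c([C@H](OC(C)(C)C)C(=O)O)c3N3CCC(C)(C)CC3)cc2)s1` differs from compound 3 by 2,4-dimethyl-1,3-thiazol-5-yl in place of 2,4,5-trifluorophenyl on a saturated chain carbon, two bonds along the chain from an oxygen on an aromatic ring. Going by the values given here, the measured steps that bear on this change are the exchanges of the aryl group at this place, a 1.0-fold higher number from compound 1 to compound 3 (0.02 log units; within the scatter) and a 2.4-fold higher number from compound 1 to compound 2 (0.38 log units; beyond the scatter), together with the single fluorine step a 2.3-fold lower number from compound 2 to compound 3 (0.36 log units; beyond the scatter). None of these exchanges brought in a ring with hetero atoms, so the data give no direct guide for the thiazolyl group. The three measured aryl variants span only a modest range, so the step of a 1.2-fold higher number from compound 3 to compound 4 (0.09 log units; within the scatter) is expected to be small, with no clear direction beyond the scatter. Compound 4 is estimated at 10 mL/min/kg, with a range from 4 mL/min/kg to 25 mL/min/kg.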

Compound 4, clearance: 30.1 mL/min/kg
For compound 4 the middle estimate is 3.0-fold (0.48 log units) below the measured one; the measured number lies above the stated range.
By their numbers in this assay, from the lowest: compounds 1 and 3 (each within the scatter of the next); then compounds 2 and 4 (each within the scatter of the next).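

At this place, on a saturated chain carbon, two bonds along the chain from an oxygen on an aromatic ring, compound 4 brings in the first ring with hetero atoms, and in this assay the exchange gives a 3.7-fold higher number from compound 3 to compound 4 (0.57 log units; beyond the scatter) and a 3.9-fold higher number from compound 1 to compound 4 (0.59 log units; beyond the scatter), both beyond the scatter, while a 1.6-fold higher number from compound 2 to compound 4 (0.21 log units; within the scatter) stays within it. The 2,4-dimethyl-1,3-thiazol-5-yl group thus groups with the 2,5-difluorophenyl of compound 2, not with the aryl groups of compound 1 and compound 3, so clearance at this place is not confined to the range of the three aryl variants. Nothing shown gives a measured reason for these steps.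

On these data alone, it remains open whether the ring hetero atoms or the two methyl groups carry the step. An unsubstituted 1,3-thiazol-5-yl or a pyridinyl ring at this place could separate the two.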